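The source may hold more compounds than are shown below. What is called first, only, known or untested is meant among the compounds shown, and "the series" means these compounds.

In a functional assay on DU-145 cells (Homo sapiens) for cytotoxicity, read by MTT assay, with a stated time of 72 h; on this read-out lower numbers stand for stronger inhibition and higher numbers for weaker inhibition:
- compound 1 `Nc1cc2nc(-c3ccccc3)nn(-c3ccccc3)c-2cc1=O`: 1830 nM
- compound 2 `O=c1cc2n(-c3ccccc3)nc(-c3ccccc3)nc-2cc1N1CCCC1`: 2460 nM
- compound 3 `CC(=O)Nc1cc2nc(-c3ccccc3)nn(-c3ccccc3)c-2cc1=O`: > 5000 nM (a limit)

Compound 3 gives no number, only a limit: the limit of > 5000 nM in this assay, at which 1 of the 3 values shown sits.

Compound 4 `CCOc1cc2nc(-c3ccccc3)nn(-c3ccccc3)c-2cc1=O` carries this change: ethoxy in place of acetamido on an aromatic carbon.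

Among the compounds with values here, no ethoxy analogue has been measured, so only the steps around acetamido bear on it. Pyrrolidin-1-yl in place of amino gave a 1.3-fold higher number from compound 1 to compound 2 (0.13 log units; within the scatter). Acetyl on the amino nitrogen gave an at least 2.7-fold higher number from compound 1 to compound 3 (0.43 log units; beyond the scatter). Acetamido in place of pyrrolidin-1-yl gave an at least 2.0-fold higher number from compound 2 to compound 3 (0.30 log units; that floor lies within the scatter). Losing acetamido is therefore expected to bring compound 4 back towards compound 1 and compound 2, a modest move to a lower number.

The expected step is an at least 1.9-fold lower number from compound 3 to compound 4 (0.28 log units; that floor lies within the scatter).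

For compound 4 the estimated value is 2600 nM, with an expected range of 1200 nM to 5000 nM.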

Compound 4, half-maximal inhibitory concentration: > 5000 nM
Compound 4: no number, only a limit; the forecaster's own chance of this, stated with the estimate: 15%; at least 1.9-fold (0.28 log units) between middle value and limit.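

In this assay, within the data shown here, compound 4 gives > 5000 nM, a limit, so acetamido is not the only group on this aromatic carbon that yields no number. Ethoxy in place of amino gives an at least 2.7-fold higher number from compound 1 to compound 4 (0.43 log units; beyond the scatter), and ethoxy in place of pyrrolidin-1-yl gives an at least 2.0-fold higher number from compound 2 to compound 4 (0.30 log units; that floor lies within the scatter). The step between acetamido and ethoxy cannot be read, and the two groups cannot be ranked: the limit of > 5000 nM in this assay, at which 2 of the 4 values shown sit.

Amino and pyrrolidin-1-yl, in compound 1 and compound 2, are the only groups here with numbers. On these data alone, whether methylamino or morpholin-4-yl would also give a number, or methoxy would also stay at a limit, remains open.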